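A few compounds are considered here, and "the series" means these few. Any claim that something is new, unique, unknown or untested is made for them only; others in the source may bear on it.

In an ADME assay on MT4 cells (Homo sapiens) for cytotoxicity, read by MTT assay, with a stated time of 4 days (on this read-out lower numbers stand for higher toxicity in this test and higher numbers for lower toxicity in this test), compound 2 `O=C(c1ccccc1)c1cc(Cl)ccc1OCCn1ccc(=O)[nH]c1=O` stands at > 337000 nM, which is a limit of the assay and not a number. With bromo in place of that chloro, compound 1 `O=C(c1ccccc1)c1cc(Br)ccc1OCCn1ccc(=O)[nH]c1=O` gives > 301000 nM, also a limit. This leaves a step that the two limits leave unreadable from compound 1 to compound 2, so the pair offers no measured size to work from.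

The next structure, compound 4 `Cc1cccc(C(=O)c2cc(Cl)ccc2OCCn2ccc(=O)[nH]c2=O)c1`, keeps the chloro of compound 2 and turns phenyl into 3-methylphenyl, with methyl in place of hydrogen on an aromatic carbon. No readable step measures this swap directly. The nearest guide is compound 3 `Cc1cc(C)cc(C(=O)c2cc(C)ccc2OCCn2ccc(=O)[nH]c2=O)c1`, which carries methyl groups and no halogen and gives a real number, 179000 nM. That value suggests a methyl-bearing relative can come within the measurable range, so only a modest shift towards lower numbers seems likely. The expected change is an at least 1.4-fold lower number from compound 2 to compound 4 (0.14 log units; that floor lies within the scatter), and its size is uncertain. For compound 4 the estimated value is 240000 nM, with an expected range from 120000 nM to 450000 nM.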

Compound 4, half-maximal cytotoxic concentration: > 325000 nM
Compound 4 was reported as a limit; the forecaster's own chance of this, stated with the estimate: 50%; middle value at least 1.3-fold (0.13 log units) from the limit.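

Compound 2 and compound 4 are both reported only as limits of the assay, not as numbers, so the step between them cannot be read. The compounds shown leave open whether methyl in place of hydrogen on an aromatic carbon changes the half-maximal cytotoxic concentration at all, and by how much.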